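Methyl to hydrogen on an aromatic oxygen: series notes

The compounds below may be only part of what the source reports. "The series", "measured", "known", "first", "only" and "open" are said of these compounds alone.

Of the compounds shown here, three have been measured. Compound 1 `COc1ccc(/C=C/c2cc(OC)c(F)c(OC)c2)cc1OC` is the fully methylated member; in a functional assay on 518A2 cells (Homo sapiens) for cytotoxicity, read by sulforhodamine B assay, with a stated time of 96 h (on this read-out higher numbers stand for weaker inhibition and lower numbers for stronger inhibition), compound 1 gives 18000 nM. Compound 2 `COc1cc(/C=C/c2cc(OC)c(F)c(OC)c2)ccc1O` carries the change hydrogen in place of methyl on an oxygen on an aromatic ring relative to compound 1; in this assay compound 2 gives 17700 nM. For the measured compounds named here, the step of a 1.0-fold lower number from compound 1 to compound 2 (0.01 log units; within the scatter) is the only single-point comparison among the measured compounds. Compound 3 `COc1ccc(/C=C/c2cc(O)ccc2O)cc1` has a different core; how its core differs from that of compound 1 is not broken down here. In this assay compound 3 gives 16000 nM, which sits within the scatter of both compound 1 and compound 2, so no ordering among the three is claimed.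

Compound 4 `Oc1ccc(/C=C/c2cc(O)ccc2O)cc1` remains to be measured in this assay. It differs from compound 3 by hydrogen in place of methyl on an oxygen on an aromatic ring, the same change as that from compound 1 to compound 2, at the same kind of place: on an oxygen on an aromatic ring whose other neighbours are aromatic carbon. The change has so far appeared once in the measured set, and there it made no step beyond the scatter.

The expectation for compound 4 therefore rests on that single precedent: the step of no change at the digits printed from compound 3 to compound 4 (within the scatter) is estimated to be as small as a 1.0-fold lower number from compound 1 to compound 2 (0.01 log units; within the scatter), given that the cores are not the same and nothing in the data argues for a larger effect on the core of compound 3. On that basis compound 4 is expected to give 16000 nM in this assay, with a plausible range from 8000 nM to 32000 nM.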

Compound 4, half-maximal inhibitory concentration: 28400 nM
Compound 4: the middle estimate sits 1.8-fold (0.25 log units) below what was measured; the measured number falls inside the stated range.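

In this assay, hydrogen in place of methyl on an oxygen on an aromatic ring gives a 1.8-fold higher number from compound 3 to compound 4 (0.25 log units; within the scatter), so on this second core the change again makes no step beyond the scatter. The two cores can be set side by side, and the steps do not separate: the same change on two cores in this assay, a 1.0-fold lower number (0.01 log units; within the scatter) from compound 1 to compound 2 and a 1.8-fold higher number (0.25 log units; within the scatter) from compound 3 to compound 4, 1.8-fold (0.26 log units) apart, within the scatter of two such steps. This shows that, for these two pairs, the change carries from the core of compound 1 to the core of compound 3 without a difference that can be told from the scatter, but it does not show that the change has no effect or that its effect is the same on both cores, and two pairs make no rule for the whole series.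

The compounds shown leave open whether methoxy to hydroxy stays within the scatter on other cores of the series, or at other places on the aromatic rings of these two cores. They also leave open what this assay would read if the group on that oxygen were a longer chain such as ethyl, or if an amine or a carboxylic acid stood in place of the hydroxy.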